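The compounds below may be only part of what the source reports. "The series", "measured", "known", "first", "only" and "open" are said of these compounds alone.

Compound 1 `CCCC(CC(=O)N1CCC(Cn2c(C)nc3cnccc32)CC1)c1ccccc1`: 11 nM
Compound 2 `Cc1nc2cnccc2n1CC1CCN(C(=O)CC(c2ccccc2)c2ccccc2)CC1`: 7.6 nM

In a functional assay (plasma) with Oryctolagus cuniculus as the target (on this read-out higher numbers stand for weaker inhibition and lower numbers for stronger inhibition), compound 1 carries the higher of the two numbers, yet the gap to compound 2 is small: a 1.4-fold lower number from compound 1 to compound 2 (0.16 log units; within the scatter). Compound 3 `Cc1nc2cnccc2n1CC1CCN(C(=O)CN(C)c2ccccc2)CC1` is the unmeasured partner of compound 1, and the change is methyl(phenyl)amino in place of 1-phenylbutyl on a saturated chain carbon bound to a carbonyl carbon. Going by the values given here, only one measured step exists, a 1.4-fold lower number from compound 1 to compound 2 (0.16 log units; within the scatter), and it bears on this only loosely: it swapped phenyl for propyl at a different place, whereas here the whole 1-phenylbutyl is exchanged for methyl(phenyl)amino, with a nitrogen now joined to the chain carbon and one hydrogen-bond acceptor entering. The measured data show that the chain bearing the aromatic ring tolerates variation, so no large change is expected, but the group entering is of a new kind, which widens the uncertainty. Compound 3 is therefore estimated at 30 nM, within 8 nM to 120 nM, a step of a 2.7-fold higher number from compound 1 to compound 3 (0.44 log units; beyond the scatter) that is expected to stay modest.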

Compound 3, half-maximal inhibitory concentration: 23 nM
Compound 3: the middle estimate sits 1.3-fold (0.12 log units) above what was measured; the measured number falls inside the stated range.
By their numbers in this assay, from the lowest: compounds 2 and 1 (each within the scatter of the next); then compound 3.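

In this assay, going by these compounds alone, the exchange of the whole 1-phenylbutyl for methyl(phenyl)amino on a saturated chain carbon bound to a carbonyl carbon gives a 2.1-fold higher number from compound 1 to compound 3 (0.32 log units; beyond the scatter) and is the first step here to lie beyond the scatter. The substituent at this place therefore does register in the read-out, yet a group with a different atom joined to the chain carbon, one hydrogen-bond acceptor and fewer heavy atoms costs only a modest step. Nothing available explains the shift, and the nitrogen, the acceptor and the smaller size of the group cannot be separated from one another.

The compounds shown leave open how phenoxy, with oxygen in place of the nitrogen, would compare with methyl(phenyl)amino. They also leave open whether ethyl(phenyl)amino, with ethyl in place of the methyl, would move the number towards that of compound 1.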